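A Chloro to Methoxy Swap in an Inactive Pair

The source may hold more compounds than are shown below. What is called first, only, known or untested is meant among the compounds shown, and "the series" means these compounds.

Compound 1 `COc1ccc(C2CC(c3ccc(Cl)cc3)=NN2c2ccc(-c3ccccc3)nn2)c(OC)c1` and compound 2 `COc1cc(C2CC(c3ccc(Cl)cc3)=NN2c2ccc(-c3ccccc3)nn2)cc(OC)c1OC` share one core and differ only in the methoxy pattern of the phenyl group on the saturated ring carbon. In a functional assay on Caco-2 cells (Homo sapiens) for antiproliferative activity, read by MTT assay, with a stated time of 24 h (a higher number here means a weaker inhibitor, a lower number a stronger inhibitor), compound 1 reaches only the assay limit > 100000 nM. In this assay compound 2 likewise stops at the limit > 100000 nM. The step that the two limits leave unreadable from compound 1 to compound 2 therefore cannot be sized, and the limit of > 100000 nM in this assay, at which 2 of the 2 values shown sit, is all the measured data offer. Compound 3 `COc1ccc(C2=NN(c3ccc(-c4ccccc4)nn3)C(c3cc(OC)c(OC)c(OC)c3)C2)cc1` is compound 2 with methoxy in place of chloro on an aromatic carbon. For the measured compounds named here, no measured step covers this change, so the expectation rests on compound 2 standing at the limit > 100000 nM. The expected step is a number no higher from compound 2 to compound 3 (the limit leaves the size open), with no readable direction. Compound 3 is estimated to give 100000 nM, between 30000 nM and 300000 nM, and most likely once more only a limit.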

Compound 3, half-maximal inhibitory concentration: > 100000 nM
Compound 3 ended at the assay's limit; the forecaster's own chance of this, stated with the estimate: 80%; the middle value lies on the limit itself.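

No size can be given for the change from compound 2 to compound 3, because both results are limits of the assay rather than numbers: the limit of > 100000 nM in this assay, at which 3 of the 3 values shown sit.

The compounds shown leave open whether either methoxy pattern, or chloro versus methoxy, makes any difference to activity in this assay.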